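A few compounds are considered here, and "the series" means these few. Any claim that something is new, unique, unknown or untested is made for them only; others in the source may bear on it.

Compound 2 `CN(Cc1ccccc1)S(=O)(=O)c1ccc(NC(=O)NCc2ccncc2)cc1` stands lowest of the three measured compounds in an assay on isolated protein for activation of Nicotinamide phosphoribosyltransferase (Homo sapiens) (on this read-out higher numbers stand for an effect only at larger amounts of compound and lower numbers for an effect already at smaller amounts), where compound 2 gives 23 nM. Compound 1 `O=C(NCc1ccncc1)Nc1ccc(S(=O)(=O)Nc2ccccc2)cc1` gives 410 nM, and compound 3 `CCOC(=O)c1ccc(NC(=O)NCc2cocn2)cc1`, built on a different core, gives 27600 nM. Compound 4 `O=C(NCc1ccncc1)Nc1ccc(S(=O)(=O)c2ccccc2Cl)cc1` arises from compound 2 by 2-chlorophenyl in place of benzyl(methyl)amino on a sulfonyl sulfur. Among the measured compounds shown here, the only measured step at this position, an 18-fold lower number from compound 1 to compound 2 (1.25 log units; beyond the scatter), shows that the group on the sulfonyl sulfur matters greatly, yet no measured compound carries a ring bound directly to that sulfur, so the step to compound 4 has no close precedent. Compound 1, which carries anilino there, gives 410 nM, and compound 4 may fall nearer to that. Compound 4 is therefore expected to give 200 nM, within a range of 40 nM to 1000 nM. This estimate means a step of an 8.7-fold higher number from compound 2 to compound 4 (0.94 log units; beyond the scatter).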

Compound 4, half-maximal effective concentration: 79 nM
Beside the measured number, compound 4's estimate is 2.5-fold (0.40 log units) above it, and the stated range covers the measured number.
By their numbers in this assay, from the lowest: compound 2; then compound 4; then compound 1; then compound 3.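

In this assay, the step of a 5.2-fold lower number from compound 1 to compound 4 (0.72 log units; beyond the scatter) shows that the sulfonyl sulfur need not carry a nitrogen-linked group for a low number, since 2-chlorophenyl, a ring bound directly to that sulfur, improves on anilino. Benzyl(methyl)amino still keeps the lowest number at this position, as a 3.4-fold higher number from compound 2 to compound 4 (0.54 log units; beyond the scatter) makes clear.

Still open, as far as these compounds go, is whether the chlorine matters, which plain phenyl could test, and how a saturated amine such as piperidine would compare on the same sulfur. No measurement available here explains either step.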